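Replacing 1,3-thiazol-5-yl with 1-methyl-1H-pyrazol-5-yl on the amide

The source may report more compounds than this note shows. Statements on the series, on what has been measured and on what is new or still open speak of the compounds shown alone.

Three amides built on a shared core have been measured. In a functional assay on MKN-28 cells (Homo sapiens) for inhibition, read by colorimetric assay and sulforhodamine B assay, with a stated time of 48 h (on this read-out higher numbers stand for weaker inhibition of growth and lower numbers for stronger inhibition of growth), compound 1 `CCCCCCCCCCCC[C@@H](O)[C@H]1CC[C@H]([C@H](O)CCCCCCCCCCNC(=O)c2ccco2)O1` gives 617 nM as its value, compound 2 `CCCCCCCCCCCC[C@@H](O)[C@H]1CC[C@H]([C@H](O)CCCCCCCCCCNC(=O)c2cncs2)O1` gives 832 nM and compound 3 `CCCCCCCCCCCC[C@@H](O)[C@H]1CC[C@H]([C@H](O)CCCCCCCCCCNC(=O)c2ccsc2)O1` gives 575 nM on the same read-out. Within the data shown here, compound 2 cannot be separated from the other two, since the data show a 1.3-fold higher number from compound 1 to compound 2 (0.13 log units; within the scatter) and also a 1.4-fold lower number from compound 2 to compound 3 (0.16 log units; within the scatter) as its only steps.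

Compound 4 `CCCCCCCCCCCC[C@@H](O)[C@H]1CC[C@H]([C@H](O)CCCCCCCCCCNC(=O)c2ccnn2C)O1` has not yet been measured. It keeps the shared core and differs from compound 2 by one group: 1-methyl-1H-pyrazol-5-yl in place of 1,3-thiazol-5-yl on a carbonyl carbon on a carbonyl carbon whose other neighbours are: amide-type nitrogen. Both groups are five-membered aromatic rings.

All three measured steps bear on this change, as each exchanges one such ring on that carbonyl carbon for another. The third is a 1.1-fold lower number from compound 1 to compound 3 (0.03 log units; within the scatter) and it also stays within the scatter. Among the measured compounds shown here, no measured compound carries the 1-methyl-1H-pyrazol-5-yl group, so this guide is indirect. In this assay no step beyond the scatter is therefore expected, and no firm direction either. The estimated step is a 1.2-fold lower number from compound 2 to compound 4 (0.08 log units; within the scatter) and it remains an expectation only. Compound 4 is expected at 700 nM on this estimate, with an expected range of 350 nM to 1400 nM around it.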

Compound 4, concentration for 50% growth inhibition: 10 nM
The estimate for compound 4 lay 70-fold (1.85 log units) above the measured number; the measured number lies below the stated range.
By their numbers in this assay, from the lowest: compound 4; then compounds 3, 1 and 2 (each within the scatter of the next).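

In this assay, the position on the carbonyl carbon had shown no separation among the furan-2-yl, 1,3-thiazol-5-yl and thiophen-3-yl groups, but the new result shows that the choice of five-membered aromatic ring here can matter greatly: there is an 83-fold lower number from compound 2 to compound 4 (1.92 log units; beyond the scatter), alongside a 58-fold lower number from compound 3 to compound 4 (1.76 log units; beyond the scatter) and a 62-fold lower number from compound 1 to compound 4 (1.79 log units; beyond the scatter). The 1,3-thiazol-5-yl and 1-methyl-1H-pyrazol-5-yl groups have the same counts of ring hetero atoms, hydrogen-bond donors and hydrogen-bond acceptors, so those counts do not separate them, whereas the entering group has 6 heavy atoms against 5 and contains no sulfur. Nothing available accounts for the large step seen with this one group.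

From the compounds shown here alone, whether the step rests on the methyl group or on the pyrazole ring itself remains open, and a pyrazole ring without the methyl, or with an ethyl group in its place, would bear directly on that question. Also open, going by these compounds, is whether the same step would appear with a shorter chain between the amide nitrogen and the shared core.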